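Fluoro-to-methyl exchange on two different cores

A few compounds are considered here, and "the series" means these few. Any claim that something is new, unique, unknown or untested is made for them only; others in the source may bear on it.

Measured compounds:
compound 1 `COc1cccc(C(=O)NCc2c(C)cc(C)[nH]c2=O)c1F` gives > 150000 nM in an assay on Sf9 cells for inhibition of histone-lysine N-methyltransferase EZH2 (Homo sapiens), read by scintillation counting, with a stated time of 60 min, in the presence of a further agent that is not named here (a lower number here means a stronger inhibitor, a higher number a weaker inhibitor), a limit of the assay and not a number.
compound 3 `COc1cccc(C(=O)NCc2c(C)cc(C)[nH]c2=O)c1C` gives 5700 nM in this assay.
compound 2 `Cc1cc(C)c(CN2CCc3c(F)cc(O[C@@H]4CCOC4)c(Cl)c3C2=O)c(=O)[nH]1` gives 56 nM in this assay.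

Going by the values given here, the one change seen twice is methyl in place of fluoro on an aromatic carbon. It is done on the core of compound 1 and gives an at least 26-fold lower number from compound 1 to compound 3 (1.42 log units; beyond the scatter); the step rests on (the limit of > 150000 nM in this assay, at which 1 of the 3 values shown sits), so only its lower bound is known.

The unmeasured compound 4 `Cc1cc(C)c(CN2CCc3c(C)cc(O[C@@H]4CCOC4)c(Cl)c3C2=O)c(=O)[nH]1` carries the same kind of change on the core of compound 2, namely (methyl in place of fluoro on an aromatic carbon). The place is not the same: in compound 1 the fluoro sits ortho to a large group and ortho to a methoxy group, whereas in compound 2 it sits ortho to a fused ring, meta to a (oxolan-3-yl)oxy group, meta to a fused ring and para to a chloro group. The difference between the two cores is not broken down here.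

Compound 2 already has the lowest number of the two measured values. Its step to compound 4 is expected to be a 1.9-fold lower number from compound 2 to compound 4 (0.27 log units; within the scatter), a smaller move than the earlier step from compound 1 to compound 3, with wide uncertainty. Compound 4 is estimated at 30 nM, between 8 nM and 150 nM.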

Compound 4, half-maximal inhibitory concentration in the histone-lysine N-methyltransferase EZH2 assay: 18 nM
Beside the measured number, compound 4's estimate is 1.7-fold (0.22 log units) above it; the range from low to high includes it.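

In the histone-lysine N-methyltransferase EZH2 assay compound 4 gives 18 nM, and methyl in place of fluoro on an aromatic carbon gives a 3.1-fold lower number from compound 2 to compound 4 (0.49 log units; beyond the scatter), the same direction as on the core of compound 1, but the size of the step does not carry over: the same change on two cores in the histone-lysine N-methyltransferase EZH2 assay, an at least 26-fold lower number (1.42 log units; beyond the scatter) from compound 1 to compound 3 and a 3.1-fold lower number (0.49 log units; beyond the scatter) from compound 2 to compound 4, at least 8.4-fold (0.92 log units) apart, beyond the scatter of two such steps

The earlier step is known only as a lower bound, as compound 1 stands at a limit of the assay: the limit of > 150000 nM in the histone-lysine N-methyltransferase EZH2 assay, at which 1 of the 4 values shown sits.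

The two cores also carry the change at different places, so these two pairs do not separate the part played by the core from that of the place, and they give no rule for a further core. In a physicochemical assay for lipophilicity, at pH 7.4 (a lower number here means a more polar compound, a higher number a more lipophilic compound), compound 2 gives 2.1 and compound 4 gives 2.1, and the exchange gives no change at the digits printed from compound 2 to compound 4 (within the scatter).

Open, from the compounds shown here alone, is whether an ethyl, a cyclopropyl or a nitrile on that aromatic carbon of the core of compound 2 would move the number in the histone-lysine N-methyltransferase EZH2 assay further than methyl does. Also open, going by these compounds, is how either core reads with plain hydrogen on that carbon, which would show how much of each step comes from losing fluoro and how much from gaining methyl.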